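Acyl versus aryl-methyl groups on the ring nitrogen

The compounds below may be only part of what the source reports. "The series", "measured", "known", "first", "only" and "open" are said of these compounds alone.

Measured compounds: compound 1 `CCCCNc1nc(N)nc2c1CCN(C(C)=O)C2`, 0.4 uM; compound 2 `CCCCNc1nc(N)nc2c1CN(Cc1c(Cl)cccc1Cl)CC2`, 0.14 uM; compound 3 `CCCCNc1nc(N)nc2c1CN(Cc1cccnc1)CC2`, 0.13 uM.

In an assay on HEK293 cells for agonist activity at Toll-like receptor 8 (Homo sapiens), read by a luciferase reporter, with a stated time of 6 h (a lower number here means that less compound is needed, a higher number that more compound is needed for the effect), compound 3 gives 0.13 uM, the lowest of the three numbers; compound 2 sits within the scatter of it, while compound 1 lies beyond the scatter with a higher number. Compound 4 `CCCCNc1nc(N)nc2c1CN(C(=O)c1scnc1C)CC2` differs from compound 3 in one place: (4-methyl-1,3-thiazol-5-yl)carbonyl in place of (pyridin-3-yl)methyl on an amine nitrogen in a ring. Among the measured compounds shown here, the only measured step, a 1.1-fold lower number from compound 2 to compound 3 (0.03 log units; within the scatter), shows that swapping one aromatic group for another on that nitrogen left the number unchanged. For the measured compounds named here, no step tests a carbonyl on this nitrogen; compound 1, which carries an acetyl group, gives 0.4 uM. For compound 4 a modestly higher number is therefore expected, a 2.3-fold higher number from compound 3 to compound 4 (0.36 log units; beyond the scatter), giving an estimate of 0.3 uM with a range from 0.1 uM to 0.9 uM.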

Compound 4, minimum effective concentration: 5.6 uM
Compound 4: the middle estimate sits 19-fold (1.27 log units) below what was measured, and the stated range ends below it.
By their numbers in this assay, from the lowest: compounds 3 and 2 (each within the scatter of the next); then compound 1; then compound 4.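

The nitrogen in the ring is not indifferent to what it carries: in this assay, replacing (pyridin-3-yl)methyl with (4-methyl-1,3-thiazol-5-yl)carbonyl gives a 43-fold higher number from compound 3 to compound 4 (1.63 log units; beyond the scatter). The earlier exchange of one aromatic group for another, a 1.1-fold lower number from compound 2 to compound 3 (0.03 log units; within the scatter), gave no sign of a change of this size. Nothing available gives a reason for this step.

From the compounds shown here alone, the carbonyl and the aromatic ring changed together, so their separate contributions remain open. A (4-methyl-1,3-thiazol-5-yl)methyl or (pyridin-3-yl)carbonyl group on this nitrogen would tell them apart.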